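Notes on compound 1 and its phenyl analogue

The source may report more compounds than this note shows. Statements on the series, on what has been measured and on what is new or still open speak of the compounds shown alone.

Measured in a functional assay on FaDu cells (Homo sapiens) for inhibition, read by sulforhodamine B assay; on this read-out higher numbers stand for weaker inhibition and lower numbers for stronger inhibition:
- compound 1 `COC(=O)CC/C(C)=C/Cc1c(OC)c(C)c2c(c1OCC#CCN1CCCc3ccccc31)C(=O)OC2`: > 50000 nM (a limit)
- compound 2 `CCCCNc1ccc(CC#CCOc2c(C/C=C(\C)CCC(=O)OC)c(OC)c(C)c3c2C(=O)OC3)cc1`: 21200 nM
- compound 3 `COC(=O)CC/C(C)=C/Cc1c(OC)c(C)c2c(c1OCC#CCN1CCC(C(=O)OC)CC1)C(=O)OC2`: > 50000 nM (a limit)

Compound 1 stands at the limit of > 50000 nM in this assay, at which 2 of the 3 values shown sit, and so has no number of its own. Only compound 2 gives a number, 21200 nM.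

Compound 4 `COC(=O)CC/C(C)=C/Cc1c(OC)c(C)c2c(c1OCC#CCN1CCC(c3ccccc3)c3ccccc31)C(=O)OC2` differs from compound 1 by one change: phenyl in place of hydrogen on a saturated ring carbon. In words, this is phenyl in place of hydrogen on a saturated ring carbon.

Going by the values given here, no measured step touches that ring carbon. The nearest evidence comes from exchanging the whole group on the saturated chain carbon bound to a triple-bonded carbon. One such exchange gave an at least 2.3-fold lower number from compound 1 to compound 2 (0.37 log units; beyond the scatter). Another gave an at least 2.3-fold higher number from compound 2 to compound 3 (0.37 log units; beyond the scatter). A third, a step that the two limits leave unreadable from compound 1 to compound 3, says nothing about size. These steps bear on the change only loosely, and both readable ones depend on compound 2. At most a modest fall in the number is therefore expected in this assay, and a result that stays at the limit is about as likely.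

The expected change is an at least 1.2-fold lower number from compound 1 to compound 4 (0.09 log units; that floor lies within the scatter).

For compound 4 the estimated value is 40000 nM, with an expected range from 15000 nM to 70000 nM.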

Compound 4, half-maximal inhibitory concentration: 24600 nM
Estimate against measurement, compound 4: 1.6-fold (0.21 log units) above, and the stated range covers the measured number.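

In this assay, phenyl in place of hydrogen on a saturated ring carbon gives compound 4 a number of its own, 24600 nM, and among the compounds shown with a ring nitrogen on the chain, compound 4 alone has one. Going by these compounds alone, this shows that a change at this ring carbon alone, with the rest of the group on the chain kept, is enough to bring the read-out off the limit, whereas the earlier compounds spoke only to exchanges of the whole group. The step is an at least 2.0-fold lower number from compound 1 to compound 4 (0.30 log units; that floor lies within the scatter), and it has only a floor, as compound 1 is a limit and not a number: the limit of > 50000 nM in this assay, at which 2 of the 4 values shown sit.

Going by these compounds, the true size of the step therefore stays open, and the floor alone does not place it beyond the usual scatter. Also open, on these data alone, is whether the gain belongs to an aromatic ring at this carbon or to any group there, which a methyl, a benzyl, a hydroxyl or an amine on the same ring carbon would help to separate, and whether phenyl would act in the same way on the piperidine ring of compound 3.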